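Replacing the chloro arm with a second methoxyphenyl arm

The source may report more compounds than this note shows. Statements on the series, on what has been measured and on what is new or still open speak of the compounds shown alone.

Compound 1 `COc1ccccc1/C=c1/[nH]c(=O)/c(=C\c2cccc(Cl)c2Cl)[nH]c1=O` stands at "not determined" (no result reported) in a functional assay on MOLT-4 cells (Homo sapiens) for cytotoxicity, read by CCK-8 assay, with a stated time of 72 h; a higher number here means a weaker inhibitor, a lower number a stronger inhibitor. Compound 2 `C=CCn1c(=O)/c(=C\c2cccc(F)c2)[nH]c(=O)/c1=C\c1ccccc1OC` gives 6500 nM in this assay, and compound 3 `C=CCn1c(=O)/c(=C\c2ccccc2Cl)[nH]c(=O)/c1=C\c1ccccc1OC` gives 4400 nM. For the measured compounds named here, compound 3 thus stands as one of only two numbers, and the step of a 1.5-fold lower number from compound 2 to compound 3 (0.17 log units; within the scatter) lies within the scatter, so the two cannot be separated. Compound 4 `C=CCn1c(=O)/c(=C\c2ccccc2OC)[nH]c(=O)/c1=C\c1ccccc1OC` differs from compound 3 by methoxy in place of chloro on an aromatic carbon. Going by the values given here, no measured step covers a methoxy entering for a chloro; the single step in hand, a 1.5-fold lower number from compound 2 to compound 3 (0.17 log units; within the scatter), exchanged one halogen arm for another and stayed within the scatter. The expectation for compound 4 is therefore a step of a 1.1-fold higher number from compound 3 to compound 4 (0.06 log units; within the scatter) in this assay, nothing beyond the scatter. Compound 4 is estimated at 5000 nM, with a range from 2000 nM to 13000 nM.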

Compound 4, half-maximal inhibitory concentration: 13100 nM
The estimate for compound 4 lay 2.6-fold (0.42 log units) below the measured number; the measured number lies above the stated range.
By their numbers in this assay, from the lowest: compounds 3, 2 and 4 (each within the scatter of the next, the first and the last beyond it).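

Methoxy in place of chloro on an aromatic carbon, ortho to a large group, gives the only step in this assay that lies beyond the scatter (a 3.0-fold higher number from compound 3 to compound 4 (0.47 log units; beyond the scatter)). The exchange of 3-fluorophenyl for 2-methoxyphenyl stays within it (a 2.0-fold higher number from compound 2 to compound 4 (0.30 log units; within the scatter)), so this arm separates compound 4 from compound 3 but not from compound 2. No measured evidence on hand bears on this result.

Still open, as far as these compounds go, is how an amine or a carboxylic acid at this place would compare. From the compounds shown here alone, whether the methoxy effect holds with a different second arm also remains open.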